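This account rests on a few compounds, and the source may have more. Where it says the series, first, only, none or still open, it means among the compounds named here.

Compound 2 `O=C(Nc1cccc(OCc2cn(-c3ccc(F)cc3)nn2)c1)Nc1ccc(Cl)c(C(F)(F)F)c1` and compound 1 `COc1cccc(-n2cc(COc3cccc(NC(=O)Nc4ccc(Cl)c(C(F)(F)F)c4)c3)nn2)c1` share one core and differ only in the group on the aromatic nitrogen. In a toxicity assay on MRC5 cells (Homo sapiens) for inhibition, read by MTT assay, with a stated time of 72 h (a higher number here means a weaker inhibitor, a lower number a stronger inhibitor), compound 1 gives 8570 nM, and in this assay compound 2 gives 4740 nM; the step of a 1.8-fold lower number from compound 1 to compound 2 (0.26 log units; within the scatter) sits within the scatter, so the two stand together. Compound 3 `O=C(Nc1cccc(OCc2cn(-c3ccccc3I)nn2)c1)Nc1ccc(Cl)c(C(F)(F)F)c1` follows from compound 2 by 2-iodophenyl in place of 4-fluorophenyl on an aromatic nitrogen. Among the measured compounds shown here, the only step that bears on this change, from compound 1 to compound 2, also swapped one aromatic ring for another at that nitrogen and stayed within the scatter, so for compound 3 an expected step of a 1.1-fold higher number from compound 2 to compound 3 (0.02 log units; within the scatter) in this assay is no more than scatter. Compound 3 is estimated at 5000 nM, expected between 2000 nM and 12000 nM.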

Compound 3, half-maximal inhibitory concentration: 21900 nM
Compound 3: the middle estimate sits 4.4-fold (0.64 log units) below what was measured, outside the stated range (above it).
By their numbers in this assay, from the lowest: compounds 2 and 1 (each within the scatter of the next); then compound 3.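

In this assay the 2-iodophenyl group on the aromatic nitrogen brings a 4.6-fold higher number from compound 2 to compound 3 (0.66 log units; beyond the scatter) and a 2.6-fold higher number from compound 1 to compound 3 (0.41 log units; beyond the scatter) in the same direction, toward a weaker inhibitor. This position therefore does respond to a change of aromatic group, which compound 1 and compound 2, within the scatter of each other, did not show. As far as these compounds go, whether the iodine itself or its place in 2-iodophenyl carries the step stays open, and so does how a phenyl ring bearing an amine or a carboxylic acid would read. No measurement at hand explains the shift.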